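Moving the methyl on a carboxycyclohexyl amide

A few compounds are considered here, and "the series" means these few. Any claim that something is new, unique, unknown or untested is made for them only; others in the source may bear on it.

Compound 1 `C[C@]1(C(=O)O)CC[C@H](C(=O)N2CC[C@](c3ccc(C(F)(C(F)(F)F)C(F)(F)F)cc3)(S(=O)(=O)c3ccc(F)cc3)C2)CC1` gives 97% in an ADME assay on microsomes from liver (Homo sapiens) for metabolic stability, with a stated time of 10 min (a lower number here means that less of the compound is left, a higher number that more of the compound is left), and lies within the scatter of compound 2 `COC[C@]1(C(=O)N2CC[C@](c3ccc(C(F)(C(F)(F)F)C(F)(F)F)cc3)(S(=O)(=O)c3ccc(F)cc3)C2)CC[C@H](C(=O)O)CC1` at 100% on the same read-out. For compound 3 `O=C(O)[C@H]1CC[C@](F)(C(=O)N2CC[C@](c3ccc(C(F)(C(F)(F)F)C(F)(F)F)cc3)(S(=O)(=O)c3ccc(F)cc3)C2)CC1` the entry reads "not determined" (no result reported) and offers no number. Compound 4 `C[C@]1(C(=O)N2CC[C@](c3ccc(C(F)(C(F)(F)F)C(F)(F)F)cc3)(S(=O)(=O)c3ccc(F)cc3)C2)CC[C@@H](C(=O)O)CC1` has the same atoms as compound 1, joined differently: 4-carboxy-1-methylcyclohexyl in place of 4-carboxy-4-methylcyclohexyl on a carbonyl carbon is the change, with 4-carboxy-1-methylcyclohexyl in place of 4-carboxy-4-methylcyclohexyl on a carbonyl carbon. Among the measured compounds shown here, the one measured step on that carbonyl carbon, which brings in 4-carboxy-1-(methoxymethyl)cyclohexyl, is a number 3 percentage points higher from compound 1 to compound 2 (within the scatter) and stays within the scatter. On that single step, the change expected in this assay is a number 2 percentage points lower from compound 1 to compound 4 (within the scatter) and nothing beyond the scatter, in no firm direction. Compound 4 is estimated at 95% with an expected range from 82% to 100% on this evidence.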

Compound 4, percent of the compound remaining: 85%
The estimate for compound 4 lay 10 percentage points above the measured number; the measured number falls inside the stated range.
By their numbers in this assay, from the lowest: compound 4; then compounds 1 and 2 (each within the scatter of the next).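

Rearranging the same atoms is enough to move the number in this assay: 4-carboxy-1-methylcyclohexyl in place of 4-carboxy-4-methylcyclohexyl gives a number 12 percentage points lower from compound 1 to compound 4 (beyond the scatter), whereas the earlier step on this carbonyl carbon stayed within the scatter. The same group in place of 4-carboxy-1-(methoxymethyl)cyclohexyl gives a number 15 percentage points lower from compound 2 to compound 4 (beyond the scatter). No measurement shown accounts for these differences.

With no number for compound 3, its step cannot be read. Also open, as far as these compounds go, is whether an ethyl group in place of the methyl in 4-carboxy-1-methylcyclohexyl would keep or lower the number.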